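A few compounds are considered here, and "the series" means these few. Any claim that something is new, unique, unknown or untested is made for them only; others in the source may bear on it.

Compound 1 `Cc1ccc(S(=O)(=O)NC(=O)c2cccnc2)cc1` gives 18500 nM
Compound 2 `O=C(NS(=O)(=O)c1ccccc1)c1cncc(C(=O)NS(=O)(=O)c2ccccc2)c1` gives 11300 nM
Compound 3 `O=C(NS(=O)(=O)c1ccc(Cl)cc1)c1cncc(C(=O)NS(=O)(=O)c2ccc(Cl)cc2)c1` gives 10600 nM

In a functional assay on B16-F10 cells (Mus musculus) for antiproliferative activity, read by colorimetric assay and MTT assay, with a stated time of 48 h (on this read-out higher numbers stand for weaker inhibition and lower numbers for stronger inhibition), compound 1 stands at 18500 nM, within the usual scatter of both compound 2 and compound 3, so these three values cannot be put in any order. The next compound, compound 4 `Cc1ccc(S(=O)(=O)NC(=O)c2ccncc2)cc1`, has not yet been measured. It differs from compound 1 by one change: pyridin-4-yl in place of pyridin-3-yl on a carbonyl carbon. Among the compounds with values here, no measured pair differs in one place only, so the data show no size for such a step. No step beyond the scatter is therefore expected in this assay. The estimated change is small, a 1.1-fold lower number from compound 1 to compound 4 (0.04 log units; within the scatter), and lies within the scatter. For compound 4 the expected value is 17000 nM, with an estimated range from 8000 nM to 40000 nM.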

Compound 4, half-maximal inhibitory concentration: 16200 nM
Estimate against measurement, compound 4: 1.0-fold (0.02 log units) above, within the range that was stated.
By their numbers in this assay, from the lowest: compounds 3, 2, 4 and 1 (each within the scatter of the next).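

In this assay, within the data shown here, pyridin-4-yl in place of pyridin-3-yl on a carbonyl carbon gives a 1.1-fold lower number from compound 1 to compound 4 (0.06 log units; within the scatter) and provides the first single-place step in this set. At this place, the two pyridinyl groups cannot be told apart, since the step lies within the scatter. No evidence is available that bears on this result.

As far as these compounds go, it remains open whether pyridin-2-yl or a plain phenyl ring on that carbonyl carbon would give a step beyond the scatter. Also open, from the compounds shown here alone, is what a methoxy group in place of the methyl group of compound 1 would do.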